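Replacing 3,4-difluorophenyl with phenyl in compound 2

A few compounds are considered here, and "the series" means these few. Any claim that something is new, unique, unknown or untested is made for them only; others in the source may bear on it.

Within the data shown here, in a functional assay on SK-N-SH cells (Homo sapiens) for cytotoxicity, read by MTT assay, with a stated time of 48 h (a higher number here means a weaker inhibitor, a lower number a stronger inhibitor), compound 1 (`COc1ccc(/C=C/c2cc(OC)c(OC)c(OC)c2-c2ccc(OC)cc2)cc1`) gives 36000 nM and compound 2 (`COc1ccc(/C=C/c2cc(OC)c(OC)c(OC)c2-c2ccc(F)c(F)c2)cc1`) gives 6900 nM, the lower of the two numbers so far. Compound 3 (`COc1ccc(/C=C/c2cc(OC)c(OC)c(OC)c2-c2ccccc2)cc1`) has not yet been measured. It departs from compound 2 by a single change, phenyl in place of 3,4-difluorophenyl on an aromatic carbon. Among the measured compounds shown here, the only measured step at this place is a 5.2-fold lower number from compound 1 to compound 2 (0.72 log units; beyond the scatter), a modest change that lies beyond the scatter. For the measured compounds named here, no measurement yet shows phenyl itself there, so that step offers only indirect guidance. On that basis, compound 3 is expected to give up part of that gain and to fall between the two measured compounds. The expected step is a 2.2-fold higher number from compound 2 to compound 3 (0.34 log units; beyond the scatter), toward a higher number and smaller than the measured one. For compound 3 the estimated value is 15000 nM, with an expected range of 6000 nM to 37000 nM.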

Compound 3, half-maximal inhibitory concentration: 11000 nM
Estimate against measurement, compound 3: 1.4-fold (0.13 log units) above; low and high end bracket the measured number.
By their numbers in this assay, from the lowest: compounds 2 and 3 (each within the scatter of the next); then compound 1.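

In this assay taking both fluorines off the ring gives a 1.6-fold higher number from compound 2 to compound 3 (0.20 log units; within the scatter) and so, at this position, 3,4-difluorophenyl and phenyl cannot be told apart. Set against the 4-methoxyphenyl compound, the plain phenyl ring gives a 3.3-fold lower number from compound 1 to compound 3 (0.51 log units; beyond the scatter) and this shows that hydrogen in place of the methoxy group is enough for a step beyond the scatter. The gain first seen with 3,4-difluorophenyl therefore does not require fluorine, and among these three compounds only compound 1, with its 4-methoxyphenyl group, stands apart.

From the compounds shown here alone, whether a hydroxyl group, an amine or a chlorine atom on this ring would move the number beyond the scatter of compound 3 remains open. No measured evidence is available to explain why the methoxy group and hydrogen differ at this position.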